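The source may hold more compounds than are shown below. What is called first, only, known or untested is meant among the compounds shown, and "the series" means these compounds.

In a physicochemical assay for solubility (a higher number here means a more soluble compound, a lower number a less soluble compound), compound 1 (`Cc1nc(-c2cc(C(F)(F)F)ccc2[C@H]2CCOc3cc(S(=O)(=O)Nc4cccc(F)n4)ccc32)co1`) gives 13000 nM as the lowest of three numbers. Higher numbers come from compound 2 (`Cc1nc(-c2cc(C(F)(F)F)ccc2[C@H]2CCOc3cc(S(=O)(=O)Nc4ncc(F)cn4)ccc32)co1`) with 281000 nM and from compound 3 (`Cc1nc(-c2cc(C(F)(F)F)ccc2[C@@H]2CCOc3cc(S(=O)(=O)Nc4nccs4)ccc32)co1`) with 130000 nM on the same scale. The unmeasured compound 4 (`Cn1nccc1-c1cc(C(F)(F)F)ccc1[C@H]1CCOc2cc(S(=O)(=O)Nc3cccc(F)n3)ccc21`) carries 1-methyl-1H-pyrazol-5-yl in place of 2-methyl-1,3-oxazol-4-yl on an aromatic carbon. For the measured compounds named here, the one measured step (a 22-fold higher number from compound 1 to compound 2 (1.33 log units; beyond the scatter)) is large, but it replaces the group on a sulfonamide nitrogen and leaves this place untouched, so it gives no size for this change. Going by the values given here, with no measured step at this place, this assay is expected to show no step beyond the scatter, in either direction. The estimated step (a 1.4-fold higher number from compound 1 to compound 4 (0.14 log units; within the scatter)) reflects that expectation. Compound 4 is estimated at 18000 nM (expected range 6000 nM to 55000 nM).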

Compound 4, solubility: 27000 nM
Estimate against measurement, compound 4: 1.5-fold (0.18 log units) below; measured number inside the range.
By their numbers in this assay, from the lowest: compound 1; then compound 4; then compound 3; then compound 2.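

At this position, on an aromatic carbon ortho to a large group, this assay now has a step of its own: a 2.1-fold higher number from compound 1 to compound 4 (0.32 log units; beyond the scatter) is modest but beyond the scatter. The two groups have the same counts of heavy atoms and hydrogen-bond acceptors, yet the number still moves. Nothing measured here bears on why it moves. From the compounds shown here alone, it remains open whether this step would hold with 5-fluoropyrimidin-2-yl on the sulfonamide nitrogen, and what an amine or a carboxylic acid on this aromatic carbon would give.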